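A few compounds are considered here, and "the series" means these few. Any claim that something is new, unique, unknown or untested is made for them only; others in the source may bear on it.

Series notes, an assay on isolated protein for inhibition of Gonadotropin-releasing hormone receptor (Homo sapiens); a higher number here means a weaker inhibitor, a lower number a stronger inhibitor:

- compound 1, `CCCn1c(SCc2cc([N+](=O)[O-])ccc2OC)nc2cc(NC(=O)NC(C)(C)C)ccc21`, 18 nM
- compound 2, `CCCn1c(SCc2cc([N+](=O)[O-])ccc2OC)nc2cc(NC(=O)NC(C)(C)C)cc(C(=O)OC)c21`, 37 nM
- compound 3, `CCCn1c(SCc2cc([N+](=O)[O-])ccc2OC)nc2cc(NC(=O)NC(C)(C)C)cc(C(=O)N(C)C)c21`, 270 nM

Compound 3 gives the highest number of the three in this assay; its nearest neighbour is compound 2 (a 7.3-fold higher number from compound 2 to compound 3 (0.86 log units; beyond the scatter)), and compound 1 is further off (a 15-fold higher number from compound 1 to compound 3 (1.18 log units; beyond the scatter)).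

Compound 4, `CCCn1c(SCc2cc([N+](=O)[O-])ccc2OC)nc2cc(NC(=O)NC(C)(C)C)cc(C(=O)NC)c21`, differs from compound 3 by hydrogen in place of methyl on an amide-type nitrogen. Going by the values given here, no measured step removes a methyl from this amide nitrogen, so the only guidance is indirect: the dimethylcarbamoyl group in place of hydrogen cost heavily (a 15-fold higher number from compound 1 to compound 3 (1.18 log units; beyond the scatter)), and the switch from methoxycarbonyl to dimethylcarbamoyl cost as well (a 7.3-fold higher number from compound 2 to compound 3 (0.86 log units; beyond the scatter)). Compound 4 keeps a carbonyl substituent at that position but a smaller one, so a number between compound 3 and compound 2 is expected, without confidence that the change clears the scatter at all. For compound 4 the step expected is a 1.8-fold lower number from compound 3 to compound 4 (0.26 log units; within the scatter), toward a lower number. The estimate for compound 4 in this assay is 150 nM, with a range from 50 nM to 450 nM.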

Compound 4, half-maximal inhibitory concentration: 41 nM
Compound 4: the middle estimate sits 3.7-fold (0.56 log units) above what was measured, outside the stated range (below it).
By their numbers in this assay, from the lowest: compound 1; then compounds 2 and 4 (each within the scatter of the next); then compound 3.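

In this assay, most of the loss carried by the dimethylcarbamoyl group goes with the second methyl on the amide-type nitrogen (a 6.6-fold lower number from compound 3 to compound 4 (0.82 log units; beyond the scatter)). Methylamino and methoxy on the carbonyl carbon cannot be told apart (a 1.1-fold higher number from compound 2 to compound 4 (0.04 log units; within the scatter)), so replacing methoxy with an amide-type nitrogen does not by itself account for the weaker number of compound 3. Methylcarbamoyl in place of hydrogen on the aromatic carbon still gives a weaker inhibitor (a 2.3-fold higher number from compound 1 to compound 4 (0.36 log units; beyond the scatter)), and nothing available explains these steps.

Open, going by these compounds, is whether removing the remaining methyl to give the unsubstituted carboxamide would keep this level, or whether an ethyl group on the amide nitrogen would already reverse it. A carboxylic acid or an aminomethyl group at this aromatic carbon would show whether any substituent there can match hydrogen.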